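The source may hold more compounds than are shown below. What is called first, only, known or untested is meant among the compounds shown, and "the series" means these compounds.

Of the compounds shown here, two carry a measured number so far. Compound 1 `COc1ccc(-c2cn3ccnc3c(-c3ccc4ncn(C5CCCCC5)c4c3)n2)cc1` gives 58.8% in a functional assay on OVCAR-5 cells (Homo sapiens) for inhibition, read by sulforhodamine B assay, with a stated time of 48 h, tested at 10 uM; a lower number here means less inhibition, a higher number more inhibition at the concentration tested (going by the name of the read-out). Compound 2 `Fc1ccc(-c2cn3ccnc3c(-c3ccc4ncn(C5CCCCC5)c4c3)n2)cc1` gives 10.3% in this assay. Within the data shown here, the one step that can be computed, a number 48.5 percentage points lower from compound 1 to compound 2 (beyond the scatter), is the single piece of evidence on the para substituent of the pendant phenyl ring. Compound 2 thus stands lowest of the two numbers, with compound 1 well beyond the scatter above it.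

The next compound, compound 3 `Clc1ccc(-c2cn3ccnc3c(-c3ccc4ncn(C5CCCCC5)c4c3)n2)cc1`, differs from compound 2 by chloro in place of fluoro on an aromatic carbon. Among the measured compounds shown here, no measured step compares two halogens at this position; the only step that bears on the position at all is the methoxy-to-fluoro change, which was large and downward. For the measured compounds named here, a chloro group is neither of those two substituents, so the step from compound 2 to compound 3 has no direct precedent. The working expectation is that compound 3 stays in the low range of this assay set by compound 2, with only a modest shift, estimated as a number 9.7 percentage points higher from compound 2 to compound 3 (within the scatter). Compound 3 is therefore expected to give about 20%, within a range of 5% to 45%.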

Compound 3, a percentage reported as inhibition, at one concentration (the size of the read-out at that concentration, not a potency): 0.84%
Compound 3: middle estimate off by 19.2 percentage points, on the high side, and the stated range ends above it.
By their numbers in this assay, from the lowest: compounds 3 and 2 (each within the scatter of the next); then compound 1.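

In this assay, the change from 4-fluorophenyl to 4-chlorophenyl gives a number 9.5 percentage points lower from compound 2 to compound 3 (within the scatter), so the two halogens are not separated at this position, a comparison the earlier pair could not offer. Among these compounds, the drop seen on leaving methoxy is no longer tied to fluoro alone: chloro at the same place gives a number 58 percentage points lower from compound 1 to compound 3 (beyond the scatter), and among the three compounds only methoxy stands clear of the low group, with no compound going against this. The data at hand offer no measurement that accounts for the gap between methoxy and the two halogens.

From the compounds shown here alone, with methoxy as the only non-halogen substituent on this aromatic carbon, it remains open whether an amine, a hydroxyl or an ethoxy group at the same place would stay near compound 1 at 58.8% or fall into the range of compound 2 and compound 3. Also open, going by these compounds, is whether methoxy keeps its clear margin over the halogens when the shared core is changed elsewhere, and whether the margin seen at this single concentration carries over to a full potency measurement.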